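A few compounds are considered here, and "the series" means these few. Any claim that something is new, unique, unknown or untested is made for them only; others in the source may bear on it.

Of the compounds shown here, two of the shared core have numbers so far. In an assay on CHO-K1 cells for displacement of a labelled ligand from melanin-concentrating hormone receptor 1 (Homo sapiens), read by scintillation proximity assay, with a stated time of 2 h (a higher number here means a weaker inhibitor, a lower number a stronger inhibitor), compound 1 `Cc1nc(N(C)C2CCCC2)nc2ccc(NC(=O)/C=C/c3ccc(Cl)cc3)cc12` gives 399 nM, the highest of the two numbers; compound 2 `Cc1nc(NCCCNS(C)(=O)=O)nc2ccc(NC(=O)/C=C/c3ccc(OC(F)(F)F)cc3)cc12` gives 54 nM, a gap beyond the scatter, though the two differ in more than one place. Compound 3 `Cc1nc(N2CCC(O)(C3CCC3)CC2)nc2ccc(NC(=O)/C=C/c3ccc(Cl)cc3)cc12` changes compound 1 in one place: 4-cyclobutyl-4-hydroxypiperidin-1-yl in place of cyclopentyl(methyl)amino on an aromatic carbon. For the measured compounds named here, no single-point step between measured compounds exists to anchor this. For compound 3 a step of a 2.0-fold lower number from compound 1 to compound 3 (0.30 log units; within the scatter) in this assay is expected, a modest move toward a stronger inhibitor that could also fall within the scatter, so the estimate is 200 nM, with a range from 60 nM to 650 nM.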

Compound 3, half-maximal inhibitory concentration: 206 nM
Beside the measured number, compound 3's estimate is 1.0-fold (0.01 log units) below it; the measured number falls inside the stated range.
By their numbers in this assay, from the lowest: compound 2; then compounds 3 and 1 (each within the scatter of the next).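

In this assay the position between two ring nitrogen atoms accepts 4-cyclobutyl-4-hydroxypiperidin-1-yl in place of cyclopentyl(methyl)amino, with a 1.9-fold lower number from compound 1 to compound 3 (0.29 log units; within the scatter). The entering group has 11 heavy atoms against 7 and 1 hydrogen-bond donor against 0, so this single change does not separate the two compounds in this read-out. No supporting data bear on this result.

Open, from the compounds shown here alone, is what a 4-cyclobutylpiperidin-1-yl group, without the hydroxyl, would give at this position. Also open, going by these compounds, is how the methanesulfonamide chain of compound 2 reads on the core of compound 1.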